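Cytotoxicity on moving fluorines around the benzyl ring

This account rests on a few compounds, and the source may have more. Where it says the series, first, only, none or still open, it means among the compounds named here.

Working notes on a small series sharing one core, read in an ADME assay on MT4 cells (Homo sapiens) for cytotoxicity, read by MTT assay; on this read-out higher numbers stand for lower toxicity in this test and lower numbers for higher toxicity in this test. Compound 1 `CCOC(=O)/C(O)=C/C(=O)c1cn(Cc2cc(F)cc(F)c2)c2cccc(OC)c12` gives 34700 nM; compound 2 `CCOC(=O)/C(O)=C/C(=O)c1cn(Cc2cccc(F)c2)c2cccc(OC)c12` gives 63200 nM; compound 3 `COc1cccc2c1c(C(=O)/C=C(\O)C(=O)O)cn2Cc1cc(F)cc(F)c1` gives 29500 nM. Compound 3 lies within the scatter of compound 1 and beyond the scatter below compound 2, whose number is higher. The two measured steps are both within the scatter: a 1.8-fold higher number from compound 1 to compound 2 (0.26 log units; within the scatter) and a 1.2-fold lower number from compound 1 to compound 3 (0.07 log units; within the scatter).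

Compound 4 `COc1cccc2c1c(C(=O)/C=C(\O)C(=O)O)cn2Cc1c(F)cccc1F` differs from compound 3 as follows: 2,6-difluorophenyl in place of 3,5-difluorophenyl on a saturated chain carbon bound to an aromatic nitrogen. Going by the values given here, no measured step moves fluorines from one place on that ring to another; the only step touching the ring, a 1.8-fold higher number from compound 1 to compound 2 (0.26 log units; within the scatter), removed a fluoro and stayed within the scatter. The change from compound 3 to compound 4 is therefore expected to give a step of a 1.0-fold higher number from compound 3 to compound 4 (0.01 log units; within the scatter) in this assay, none beyond the scatter in either direction. For compound 4 the estimate in this assay is 30000 nM, with a range from 14000 nM to 65000 nM.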

Compound 4, half-maximal cytotoxic concentration: 44300 nM
Compound 4: middle estimate off by 1.5-fold (0.17 log units), on the low side, and the stated range covers the measured number.
By their numbers in this assay, from the lowest: compounds 3, 1, 4 and 2 (each within the scatter of the next, the first and the last beyond it).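

Moving the two fluoro groups from 3,5-difluorophenyl to 2,6-difluorophenyl on a saturated chain carbon bound to an aromatic nitrogen is the first change in the series that rearranges this ring while keeping its atoms, and in this assay it gives a 1.5-fold higher number from compound 3 to compound 4 (0.18 log units; within the scatter) and no separation beyond the scatter. For this pair, the placement of the two fluoro groups therefore does not distinguish the compounds on this read-out. No supporting data bear on this result.

Still open, going by these compounds, is whether the same rearrangement would read alike with ethyl in place of hydrogen on the oxygen next to a carbonyl group, as in compound 1. Also open, on these data alone, is how this ring would read with chloro or trifluoromethyl in place of fluoro.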